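Cyano replacing trifluoromethoxy in the shared core series

The source may hold more compounds than are shown below. What is called first, only, known or untested is meant among the compounds shown, and "the series" means these compounds.

Compound 3 (`CN(C)CC[C@H](CSc1ccccc1)Nc1ccc(S(=O)(=O)NC(=O)c2ccc(N3CCN(Cc4ccccc4-c4ccc(Cl)cc4)CC3)cc2)cc1OC(F)(F)F`) is the parent of this step. In an assay on isolated protein for displacement of a labelled ligand from Apoptosis regulator Bcl-2 (Homo sapiens), read by fluorescence polarization (a higher number here means a weaker inhibitor, a lower number a stronger inhibitor), compound 3 gives < 1 nM, which is a limit of the assay rather than a number. Compound 1 (`CN(C)CC[C@H](CSc1ccccc1)Nc1ccc(S(=O)(=O)NC(=O)c2ccc(N3CCN(Cc4ccccc4-c4ccc(Cl)cc4)CC3)cc2)cc1C(F)(F)F`) carries trifluoromethyl at the same aromatic carbon; in this assay compound 1 gives < 1 nM, again a limit. Compound 2 (`CN(C)CC[C@H](CSc1ccccc1)Nc1ccc(S(=O)(=O)NC(=O)c2ccc(N3CCN(Cc4ccccc4-c4ccc(Cl)cc4)CC3)cc2)cc1S(=O)(=O)C(F)(F)F`) carries (trifluoromethyl)sulfonyl there; in this assay compound 2 gives < 1 nM, also a limit. The steps a step that the two limits leave unreadable from compound 1 to compound 2, a step that the two limits leave unreadable from compound 1 to compound 3 and a step that the two limits leave unreadable from compound 2 to compound 3 therefore cannot be sized, since (the limit of < 1 nM in this assay, at which 3 of the 3 values shown sit). Compound 4 (`CN(C)CC[C@H](CSc1ccccc1)Nc1ccc(S(=O)(=O)NC(=O)c2ccc(N3CCN(Cc4ccccc4-c4ccc(Cl)cc4)CC3)cc2)cc1C#N`) differs from compound 3 by cyano in place of trifluoromethoxy on an aromatic carbon. For the measured compounds named here, no measured step gives a readable direction for this change; three different groups at this carbon all sit at the limit. The step of a number no lower from compound 3 to compound 4 (the limit leaves the size open) is expected to be none beyond the scatter. Compound 4 is estimated at 1 nM in this assay, with a range from 0.3 nM to 5 nM, and is expected most likely to be reported again as a limit.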

Compound 4, inhibition constant: < 1 nM
Compound 4: only a limit was reported (the forecaster's own chance of this, stated with the estimate: 60%); the middle value sits exactly at the limit.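

The steps linking compound 4 with compound 1, compound 2 and compound 3 cannot be read in this assay, because all four values are limits: the limit of < 1 nM in this assay, at which 4 of the 4 values shown sit.

Going by these compounds, whether trifluoromethyl, (trifluoromethyl)sulfonyl, trifluoromethoxy and cyano at this aromatic carbon differ at all in this assay stays open.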